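Triazolylmethyl aryl swap on the aminocyano spiro series

A few compounds are considered here, and "the series" means these few. Any claim that something is new, unique, unknown or untested is made for them only; others in the source may bear on it.

The series shares a spiro core carrying an amino nitrile and an aminophenyl-substituted fused ring; its members differ in the aryl group on the triazole nitrogen. Compound 1 `N#CC1=C(N)Oc2c(c3nc4ccccc4nc3c3ccccc23)C12C(=O)N(Cc1cnnn1-c1ccc(Cl)cc1)c1ccccc12` carries a 4-chlorophenyl there, compound 2 `N#CC1=C(N)Oc2c(c3nc4ccccc4nc3c3ccccc23)C12C(=O)N(Cc1cnnn1-c1ccc(F)c(Cl)c1)c1ccccc12` a 3-chloro-4-fluorophenyl, and compound 3 `N#CC1=C(N)Oc2c(N)cc3nc4ccccc4nc3c2C12C(=O)N(Cc1cnnn1-c1ccc(Cl)cc1)c1ccccc12` adds an amino group on the fused ring while keeping the 4-chlorophenyl. In an ADME assay on HUVEC cells (Homo sapiens) for antiproliferative activity, read by MTT assay, with a stated time of 48 h (a higher number here means a weaker inhibitor, a lower number a stronger inhibitor), compound 1 reports only a limit, > 50000 nM. Compound 2 likewise reports only a limit in this assay, > 50000 nM. Compound 3 also stands at a limit in this assay, > 50000 nM. For the measured compounds named here, the one step between neighbours, a step that the two limits leave unreadable from compound 1 to compound 2, cannot be sized, and the three values together sit at the limit of > 50000 nM in this assay, at which 3 of the 3 values shown sit.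

Compound 4 `COc1ccc(OC)c(-n2nncc2CN2C(=O)C3(C(C#N)=C(N)Oc4c(N)cc5nc6ccccc6nc5c43)c3ccccc32)c1` differs from compound 3 by 2,5-dimethoxyphenyl in place of 4-chlorophenyl on an aromatic nitrogen. Going by the values given here, the only measured step that touches the same position, from compound 1 to compound 2, is unreadable, so no size or direction can be taken from it. Among the compounds with values here, with every value so far at the limit, compound 4 is expected to stay there as well, and the expected step that the limit leaves unreadable from compound 3 to compound 4 is one that no reading here can resolve. Compound 4 is therefore estimated at 70000 nM, with a range from 20000 nM to 250000 nM.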

Compound 4, half-maximal inhibitory concentration: > 50000 nM
Compound 4 gave a limit, no number (the forecaster's own chance of this, stated with the estimate: 80%); the middle value lies beyond the limit too.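

Compound 3 and compound 4 both report only a limit, not a number, in this assay, so no step can be read between them: the limit of > 50000 nM in this assay, at which 4 of the 4 values shown sit.

The compounds shown leave open how far any aryl group on that aromatic nitrogen changes antiproliferative activity in this assay, as none of them gives a number there.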